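The source may report more compounds than this note shows. Statements on the series, on what has been measured and on what is new or still open speak of the compounds shown alone.

Compound 1 `CC(C)(C)c1cc(/C=C/C(=O)NCCC2CCN(Cc3ccccc3)CC2)cc(C(C)(C)C)c1O` belongs to a set of three measured analogues that share one core and differ only in the group on the benzyl ring. In an assay on isolated protein for inhibition of Amine oxidase [flavin-containing] A (Homo sapiens), read by fluorescence, with stated times of 15 min and 20 min (on this read-out higher numbers stand for weaker inhibition and lower numbers for stronger inhibition), compound 1 gives 62300 nM, the lowest of the three numbers seen, though its neighbours sit within the scatter of it. Compound 2 `Cc1ccc(CN2CCC(CCNC(=O)/C=C/c3cc(C(C)(C)C)c(O)c(C(C)(C)C)c3)CC2)cc1` gives 70100 nM in this assay, and compound 3 `CC(C)(C)c1cc(/C=C/C(=O)NCCC2CCN(Cc3ccc(Br)cc3)CC2)cc(C(C)(C)C)c1O` gives 73200 nM. The steps among them are all small: a 1.1-fold higher number from compound 1 to compound 2 (0.05 log units; within the scatter), a 1.2-fold higher number from compound 1 to compound 3 (0.07 log units; within the scatter) and a 1.0-fold higher number from compound 2 to compound 3 (0.02 log units; within the scatter). Compound 4 `CC(C)(C)c1cc(/C=C/C(=O)NCCC2CCN(Cc3cccc([N+](=O)[O-])c3)CC2)cc(C(C)(C)C)c1O` is the unmeasured member; it differs from compound 1 by nitro in place of hydrogen on an aromatic carbon, the nitro group entering on an aromatic carbon of the same ring that carries methyl in compound 2 and bromo in compound 3. Because a 1.1-fold higher number from compound 1 to compound 2 (0.05 log units; within the scatter) and a 1.2-fold higher number from compound 1 to compound 3 (0.07 log units; within the scatter) both stayed within the scatter, no step beyond the scatter is expected in this assay from compound 1 to compound 4 either, a 1.1-fold higher number from compound 1 to compound 4 (0.04 log units; within the scatter). Compound 4 is therefore estimated at 68000 nM, with a range from 32000 nM to 145000 nM.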

Compound 4, half-maximal inhibitory concentration: 70900 nM
Compound 4: the middle estimate sits 1.0-fold (0.02 log units) below what was measured; the measured number falls inside the stated range.
By their numbers in this assay, from the lowest: compounds 1, 2, 4 and 3 (each within the scatter of the next).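

In this assay, nitro entering as 3-nitrobenzyl, with 3 heavy atoms in place of a hydrogen, still leaves the number within the scatter of the unsubstituted benzyl (a 1.1-fold higher number from compound 1 to compound 4 (0.06 log units; within the scatter)). Exchanging 4-methylphenyl or 4-bromophenyl for 3-nitrophenyl changes both the group and its ring position, yet these steps also stay within the scatter (a 1.0-fold higher number from compound 2 to compound 4 (0.00 log units; within the scatter); a 1.0-fold lower number from compound 3 to compound 4 (0.01 log units; within the scatter)). Nothing available explains why the numbers stay so close together.

The compounds shown leave open whether an amine or a carboxylic acid on this ring would bring a step beyond the scatter. They also leave open whether a longer chain between the ring and the amine nitrogen would do so.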